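From Propoxy to Methylsulfanyl on a Shared Core

The compounds below may be only part of what the source reports. "The series", "measured", "known", "first", "only" and "open" are said of these compounds alone.

Compound 3 `CCCOc1nc(N)c2nc(O)n(Cc3ccccc3)c2n1` stands lowest of the three compounds measured in a functional assay (spleen, spleen) for activation, with Mus musculus as the target (on this read-out lower numbers stand for an effect already at smaller amounts and higher numbers for an effect only at larger amounts of compound), giving 0.01 uM. Compound 1 `CCCCNc1nc(N)c2nc(O)n(Cc3ccccc3)c2n1` gives 1 uM and compound 2 `CCCc1nc(N)c2nc(O)n(Cc3ccccc3)c2n1` gives 1 uM; the step of no change at the digits printed from compound 1 to compound 2 (within the scatter) lies within the scatter. Both steps that lead to compound 3 are large: a 100-fold lower number from compound 1 to compound 3 (2.00 log units; beyond the scatter) and a 100-fold lower number from compound 2 to compound 3 (2.00 log units; beyond the scatter).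

Compound 4 `CSc1nc(N)c2nc(O)n(Cc3ccccc3)c2n1` differs from compound 3 in one place: methylsulfanyl in place of propoxy on an aromatic carbon. For the measured compounds named here, no measured compound carries methylsulfanyl, so no recorded step speaks to sulfur directly. What the measured steps do show is that propoxy, set against either butylamino or propyl, goes with the lowest number, as a 100-fold lower number from compound 1 to compound 3 (2.00 log units; beyond the scatter) and a 100-fold lower number from compound 2 to compound 3 (2.00 log units; beyond the scatter) record; taking propoxy away therefore gives reason to expect a higher number in this assay for compound 4. Going by the values given here, how far toward the level of compound 1 and compound 2 it rises remains open, since sulfur has no precedent here. The expected step is a 30-fold higher number from compound 3 to compound 4 (1.48 log units; beyond the scatter), a rise beyond the scatter but not necessarily all the way back. Compound 4 is accordingly estimated at 0.3 uM, with a range from 0.03 uM to 3 uM.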

Compound 4, minimum effective concentration: 0.1 uM
Compound 4: the middle estimate sits 3.0-fold (0.48 log units) above what was measured; low and high end bracket the measured number.
By their numbers in this assay, from the lowest: compound 3; then compound 4; then compounds 1 and 2 (each within the scatter of the next).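

Up to this point the aromatic carbon between two ring nitrogen atoms had shown only two levels in this assay, and methylsulfanyl now gives a third level that lies clearly apart from both (a 10-fold higher number from compound 3 to compound 4 (1.00 log units; beyond the scatter)). The new group keeps part of the advantage over the other two substituents (a 10-fold lower number from compound 2 to compound 4 (1.00 log units; beyond the scatter); a 10-fold lower number from compound 1 to compound 4 (1.00 log units; beyond the scatter)), so the response at this position is graded and not limited to propoxy against everything else, although only four substituents are compared. None of the information available here accounts for these differences in the read-out.

The step from propoxy to methylsulfanyl exchanges oxygen for sulfur and, at the same time, goes from 4 heavy atoms to 2, so the compounds shown cannot tell which of these changes goes with the higher number; methoxy and propylsulfanyl on the same carbon would pull the two apart. As far as these compounds go, how the number moves with a longer chain on either atom, such as butoxy or butylsulfanyl, also remains open.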